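The compounds below may be only part of what the source reports. "The series", "measured", "known", "first", "only" and "open" are said of these compounds alone.

Compounds measured so far: compound 1 `CC#CCC(C)[C@H](O)/C=C/[C@H]1[C@H](O)C[C@]2(C#CCCCN=[N+]=[N-])C/C(=C\CCCC(=O)O)C[C@H]12` with 20 nM in a functional assay for inhibition, with Homo sapiens as the target (on this read-out lower numbers stand for stronger inhibition and higher numbers for weaker inhibition), and compound 2 `CC#CCC(C)[C@H](O)/C=C/[C@H]1[C@H](O)C[C@]2(C#CCCCI)C/C(=C\CCCC(=O)O)C[C@H]12` with 5 nM in this assay.

Within the data shown here, compound 2 stands at the lowest number of the two, with compound 1 the only neighbour, as the step of a 4.0-fold lower number from compound 1 to compound 2 (0.60 log units; beyond the scatter) shows. Compound 3 `CC#CCC(C)[C@H](O)/C=C/[C@H]1[C@H](O)C[C@]2(C#CCCC(=O)O)C/C(=C\CCCC(=O)O)C[C@H]12` differs from compound 2 by the change (carboxy in place of iodomethyl on a saturated chain carbon, two bonds along the chain from a triple-bonded carbon). Among the measured compounds shown here, no measured step touches this kind of exchange; the one step known concerns a different group at a different chain carbon and is modest. Compound 3 is therefore expected to move moderately toward higher numbers, as a 4.0-fold higher number from compound 2 to compound 3 (0.60 log units; beyond the scatter), with wide uncertainty.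

Compound 3 is estimated at 20 nM, between 4 nM and 100 nM.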

Compound 3, half-maximal inhibitory concentration: 2000 nM
Compound 3: the middle estimate sits 100-fold (2.00 log units) below what was measured; the whole stated range lies below it.
By their numbers in this assay, from the lowest: compound 2; then compound 1; then compound 3.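

In this assay, this position on the chain proves far from indifferent to what it carries: carboxy in place of iodomethyl gives a 400-fold higher number from compound 2 to compound 3 (2.60 log units; beyond the scatter), and carboxy in place of azidomethyl gives a 100-fold higher number from compound 1 to compound 3 (2.00 log units; beyond the scatter). Among these compounds, both steps are large, whereas the one earlier exchange at the chain end, a 4.0-fold lower number from compound 1 to compound 2 (0.60 log units; beyond the scatter), is modest. No evidence is available to explain this loss.

The compounds shown leave open whether the loss follows from the carboxy group itself, and whether its methyl ester, a primary amide or an amine would return to the lower numbers.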